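This account rests on a few compounds, and the source may have more. Where it says the series, first, only, none or still open, it means among the compounds named here.

In a functional assay on MT4 cells (Homo sapiens) for cytotoxicity (a higher number here means that more compound is tolerated, a lower number that less compound is tolerated), compound 1 `CCC(c1cc(O)nc(SC(C)C)n1)c1cccc2ccccc12` gives 16900 nM, and compound 3 `CC(c1cc(O)nc(SC2CCCCC2)n1)c1cccc2ccccc12` gives 45000 nM, the higher of these two numbers and beyond the scatter from compound 1. Compound 2 `CCC(c1cc(O)nc(SC2CCCC2)n1)c1cccc2ccccc12` reads > 200000 nM, which is a limit and not a number. Compound 4 `CCC(c1cc(O)nc(SC2CCCCC2)n1)c1cccc2ccccc12` differs from compound 3 by methyl in place of hydrogen on a saturated chain carbon, two bonds along the chain from two aromatic carbons, which reads as methyl to ethyl. Among the measured compounds shown here, the one measured step, an at least 11-fold higher number from compound 1 to compound 2 (1.07 log units; beyond the scatter), is large, but it lies on the sulfur and not on this chain carbon, so it bears only indirectly. For the measured compounds named here, no measured step covers the change itself. With compound 3 at 45000 nM as the anchor, only a small upward move in this assay is expected, and the estimated step is a 1.6-fold higher number from compound 3 to compound 4 (0.19 log units; within the scatter). For compound 4 the expected value is 70000 nM, with an estimated range of 22000 nM to 200000 nM.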

Compound 4, half-maximal cytotoxic concentration: 23400 nM
Compound 4: the middle estimate sits 3.0-fold (0.48 log units) above what was measured; low and high end bracket the measured number.
By their numbers in this assay, from the lowest: compounds 1, 4 and 3 (each within the scatter of the next, the first and the last beyond it). At a limit, above all of these: compound 2.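

Methyl to ethyl on the saturated chain carbon gives a 1.9-fold lower number from compound 3 to compound 4 (0.28 log units; within the scatter) in this assay and so leaves this position without a shift beyond the scatter. With ethyl on that carbon, cyclohexyl in place of cyclopentyl on the sulfur gives an at least 8.5-fold lower number from compound 2 to compound 4 (0.93 log units; beyond the scatter) and cyclohexyl in place of isopropyl gives a 1.4-fold higher number from compound 1 to compound 4 (0.14 log units; within the scatter) here, so among these sulfur groups only cyclopentyl stands apart. The reading for compound 2 is a limit and not a number: the limit of > 200000 nM in this assay, at which 1 of the 4 values shown sits.

Going by these compounds, whether cyclopentyl stands apart with methyl on the chain carbon stays open. So does the outcome for a longer chain such as propyl at that carbon.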